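Acetyl in place of benzyl: expectation for compound 3

The source may report more compounds than this note shows. Statements on the series, on what has been measured and on what is new or still open speak of the compounds shown alone.

Measured so far:
compound 1, `C=CCn1c(=S)n(C2OC(COCc3ccccc3)[C@H]3OC(C)(C)O[C@@H]23)c2nc(N)nc(O)c21`, 77%
compound 2, `C=CCn1c(=O)n(C2OC(CO[Si](C)(C)C(C)(C)C)[C@@H](O)[C@H]2O)c2nc(N)nc(O)c21`, 5%

In a functional assay on the whole organism (B cells) with Mus musculus as the target (on this read-out higher numbers stand for larger maximal responses and lower numbers for smaller maximal responses), compound 1 gives 77%, the higher of the two numbers; compound 2 gives 5%, a gap beyond the scatter. Compound 3, `C=CCn1c(=S)n(C2OC(COC(C)=O)[C@H]3OC(C)(C)O[C@@H]23)c2nc(N)nc(O)c21`, is not yet measured and differs from compound 1 by acetyl in place of benzyl on an oxygen on a saturated carbon. Among the measured compounds shown here, no step between measured compounds touches this place alone, and compound 2 differs from compound 1 in several places, so it gives no guide. A modest downward step of a number 17 percentage points lower from compound 1 to compound 3 (beyond the scatter) is expected, though none beyond the scatter is possible. For compound 3 the estimate is 60%, in the range 25% to 90%.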

Compound 3, largest response reached (reported as maximal response), in percent of the reference or control that the assay uses: 141%
Compound 3: middle estimate off by 81 percentage points, on the low side, and the stated range ends below it.
By their numbers in this assay, from the lowest: compound 2; then compound 1; then compound 3.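

In this assay, acetyl in place of benzyl on an oxygen on a saturated carbon gives a number 64 percentage points higher from compound 1 to compound 3 (beyond the scatter), so the response at this position depends strongly on the group carried by that oxygen. The benzyl group and its aromatic ring are not required for a large maximal response on the core of compound 1. Nothing available accounts for the size or direction of this step. Open: whether the gain follows from the acetyl carbonyl or from the loss of benzyl. A methyl ether, a free hydroxyl and a longer acyl chain such as butanoyl on this oxygen would separate these readings.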